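A Smaller Halogen at the Same Aromatic Position

The source may hold more compounds than are shown below. What is called first, only, known or untested is meant among the compounds shown, and "the series" means these compounds.

Among the measured compounds shown here, compound 1, `CC1(C)C(=O)N(c2ccc(Cl)cc2)c2ncccc21`, has the higher number of the two compounds measured so far. In a functional assay on the whole organism with Rattus norvegicus as the target, at a dose of 25 mg/kg (a higher number here means more inhibition at the dose given (going by the name of the read-out), a lower number less inhibition), compound 1 gives 65%. For the measured compounds named here, its only measured companion is compound 2, `CC1(C)C(=O)N(c2cccc(Cl)c2)c2ncccc21`, which in this assay gives 31%, a clearly lower number that lies beyond the usual scatter of such measurements. Going by the values given here, compound 1 therefore stands highest of the two values known, and no computed step between the two compounds is available, so only their two values speak.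

The unmeasured compound 3, `CC1(C)C(=O)N(c2ccc(F)cc2)c2ncccc21`, keeps the core of compound 1 and differs from it in one place: fluoro in place of chloro on an aromatic carbon. Among the compounds with values here, with no measured step of this kind to lean on, the size of the change is open. The author expects the step from compound 1 to compound 3 to be small, a number 10 percentage points lower from compound 1 to compound 3 (within the scatter), a modest fall or none beyond the scatter. Compound 3 is accordingly estimated at 55%, with a range from 30% to 78%.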

Compound 3, a percentage reported as inhibition, in the whole organism at one dose (the size of the read-out at that dose, not a potency): 48%
Compound 3: the middle estimate sits 7 percentage points above what was measured; the measured number falls inside the stated range.
By their numbers in this assay, from the lowest: compound 2; then compound 3; then compound 1.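

Among the compounds shown here, with this step the halogen itself changes for the first time on the aromatic carbon para to a large group, and in this assay fluoro in place of chloro gives a number 17 percentage points lower from compound 1 to compound 3 (beyond the scatter). The identity of the halogen at this position therefore matters, a point that the earlier pair of compounds could not show, since those two carry chloro in both cases. For the compounds shown here, the fall is modest, however, and compound 3 (48%) keeps a clear read-out at the dose given, so chloro is not the only group at this position that leaves inhibition in place, although nothing available explains why the number falls with this exchange.

The compounds shown leave open whether the trend seen with these two halogens continues to bromo or iodo, or whether a methyl, a methoxy or a trifluoromethyl group at the same carbon would match chloro. They also leave open how an amine or a carboxylic acid would fare there, and whether fluoro in place of chloro would give a step of similar size at any other position on this ring.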